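Removal of the isopropyl group in a thyromimetic series

The source may hold more compounds than are shown below. What is called first, only, known or untested is meant among the compounds shown, and "the series" means these compounds.

Measured compounds:
compound 1, `CC(C)c1cc(Oc2c(C(C)C)cc(CC3SC(=O)NC3=O)cc2C(C)C)ccc1O`, 70 nM
compound 2, `Cc1cc2c(CC(=O)O)coc2c(C)c1Oc1ccc(O)c(C(C)C)c1`, 0.3 nM
compound 3, `CC(C)c1cc(Oc2ccc3oc(C(=O)O)cc3c2)ccc1O`, 1000 nM

The three numbers come from a functional assay on HepG2 cells for agonist activity at thyroid hormone receptor (Homo sapiens); on this read-out higher numbers stand for an effect only at larger amounts of compound and lower numbers for an effect already at smaller amounts. On this read-out compound 2 gives the lowest number of the three; compound 1 and compound 3 both give higher numbers, and both gaps to compound 2 lie beyond the scatter, so compound 2 is the most potent of the measured set.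

Compound 4, `Cc1cc2c(CC(=O)O)coc2c(C)c1Oc1ccc(O)cc1`, has not been measured. It differs from compound 2 in one place: hydrogen in place of isopropyl on an aromatic carbon. Going by the values given here, no pair of measured compounds differs by this change alone, so nothing measured shows what it does in this assay; the expectation can rest only on the value of compound 2.

Given that compound 2 gives 0.3 nM in this assay, compound 4 is expected to give a higher number, and the step from compound 2 to compound 4 is estimated as a 33-fold higher number from compound 2 to compound 4 (1.52 log units; beyond the scatter), beyond the scatter. For compound 4 the estimate is 10 nM, with a range from 1 nM to 100 nM.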

Compound 4, half-maximal effective concentration: 1000 nM
Compound 4: the middle estimate sits 100-fold (2.00 log units) below what was measured; the whole stated range lies below it.
By their numbers in this assay, from the lowest: compound 2; then compound 1; then compounds 3 and 4 (each within the scatter of the next).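

In this assay, going by these compounds alone, hydrogen in place of isopropyl on the aromatic carbon ortho to a hydroxy group gives a 3300-fold higher number from compound 2 to compound 4 (3.52 log units; beyond the scatter) as the first step read from a single change. Within the data shown here, the earlier compounds differ from each other in more than one place, so only this pair isolates the position, and it shows that the potency of compound 2 depends heavily on keeping isopropyl there. No available measurement bears on why the step is this large.

Open, going by these compounds, is how the position responds to groups of intermediate or greater size, such as methyl, ethyl or tert-butyl. Also open, on these data alone, is whether the same removal has a comparable effect on the cores of compound 1 and compound 3, which carry isopropyl ortho to their hydroxy group.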